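Swapping Nitro for Amino on a Sulfonamide Aryl Group

The source may hold more compounds than are shown below. What is called first, only, known or untested is meant among the compounds shown, and "the series" means these compounds.

Going by the values given here, in a functional assay on DU-145 cells (Homo sapiens) for cytotoxicity, read by trypan blue exclusion, with a stated time of 96 h (on this read-out lower numbers stand for stronger inhibition and higher numbers for weaker inhibition), compound 3 (`COc1cc(OC)c(/C=C/S(=O)(=O)Nc2ccc(OC)c([N+](=O)[O-])c2)c(OC)c1`) gives 2500 nM, the second highest of the three numbers so far. Compound 2 (`COc1cc(OC)c(/C=C/S(=O)(=O)Nc2ccc(OC)c(O)c2)c(OC)c1`) gives 30 nM, and compound 1 (`COc1cc(OC)c(/C=C/S(=O)(=O)Nc2ccc(F)c(N)c2)c(OC)c1`) gives 10000 nM.

Compound 4 (`COc1cc(OC)c(/C=C/S(=O)(=O)Nc2ccc(OC)c(N)c2)c(OC)c1`) departs from compound 3 in one place: amino in place of nitro on an aromatic carbon. The change falls ortho to a methoxy group. Among the compounds with values here, two measured steps bear on this. The closer is an 83-fold higher number from compound 2 to compound 3 (1.92 log units; beyond the scatter), in which nitro replaced hydroxy, so a large swing in this assay has already followed a change of nitro for another group. The other is a 330-fold lower number from compound 1 to compound 2 (2.52 log units; beyond the scatter), with 3-hydroxy-4-methoxyphenyl in place of 3-amino-4-fluorophenyl. That step alters two groups at once and cannot isolate the amino group. It does caution that an amino group offers no assurance of a low number, since compound 1 carries one and gives 10000 nM. Within the data shown here, no measured compound yet pairs amino with methoxy.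

The expected outcome is a large move towards a lower number, stopping short of a full return to the level of the hydroxy compound: a 31-fold lower number from compound 3 to compound 4 (1.49 log units; beyond the scatter). Compound 4 is estimated at 80 nM, with an expected range of 15 nM to 500 nM.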

Compound 4, half-maximal inhibitory concentration: 5 nM
For compound 4 the middle estimate is 16-fold (1.20 log units) above the measured one; the measured number lies below the stated range.
By their numbers in this assay, from the lowest: compound 4; then compound 2; then compound 3; then compound 1.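

In this assay the change a 500-fold lower number from compound 3 to compound 4 (2.70 log units; beyond the scatter) shows that this aromatic carbon, ortho to a methoxy group, responds strongly when amino enters in place of nitro, and the result goes further than a return to the level of the hydroxy compound. The step of a 6.0-fold lower number from compound 2 to compound 4 (0.78 log units; beyond the scatter) lies beyond the scatter and places amino ahead of hydroxy at this position, so compound 4 now holds the lowest number of the four compounds. The step of a 2000-fold lower number from compound 1 to compound 4 (3.30 log units; beyond the scatter) holds the amino group fixed and changes only fluoro to methoxy, which shows that amino at this position gives a low number with methoxy present but not with fluoro present, and so the effect of the amino group depends on the group that accompanies it.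

Nothing measured here accounts for the size of these steps. From the compounds shown here alone, it remains open whether a methylamino or dimethylamino group, or an acetamide, at this position would keep a number as low as that of the free amino group, and whether an ethoxy group or a chlorine atom could stand in for the methoxy group.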